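Swapping an Ether for a Pyrrolidine-Bearing Chain

The source may hold more compounds than are shown below. What is called first, only, known or untested is meant among the compounds shown, and "the series" means these compounds.

Measured compounds:
- compound 1, `CCOC(=O)c1ccnc(-c2ccc(OCC)cc2)c1`: 87%
- compound 2, `CCOC(=O)c1cccc(-c2ccc(OC)cc2)c1`: 77%

In an assay on COS-7 cells for inhibition of patatin-like phospholipase domain-containing protein 2 (Mus musculus), tested at 200 uM (on this read-out lower numbers stand for less inhibition and higher numbers for more inhibition at the one concentration tested (going by the name of the read-out)), compound 1 gives 87%, and in this assay compound 2 gives 77%. Compound 2 stands at the lower end of the two numbers shown, but compound 1 lies within the usual scatter of it, so the two cannot be told apart on this read-out and no ranking between them is claimed.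

The unmeasured compound 3, `CCOC(=O)c1cccc(-c2ccc(CN3CCCC3)cc2)c1`, shares the core of compound 2 and differs from it in one place: (pyrrolidin-1-yl)methyl in place of methoxy on an aromatic carbon. No step between measured compounds covers a change of this kind, so there is nothing among the measured pairs from which its size could be read. The expectation for compound 3 is therefore only modestly below compound 2, with the step of a number 7 percentage points lower from compound 2 to compound 3 (within the scatter) expected to stay within the scatter or just beyond it. In this assay compound 3 is estimated at 70%, with a range from 40% to 95%.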

Compound 3, a percentage reported as inhibition, at one concentration (the size of the read-out at that concentration, not a potency): 33%
The estimate for compound 3 lay 37 percentage points above the measured number, and the stated range ends above it.
By their numbers in this assay, from the lowest: compound 3; then compounds 2 and 1 (each within the scatter of the next).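

In this assay, replacing methoxy with (pyrrolidin-1-yl)methyl on an aromatic carbon para to a large group gives a number 44 percentage points lower from compound 2 to compound 3 (beyond the scatter). Within the data shown here, this is the first step here between compounds differing in one place, and it shows that the read-out at this position depends strongly on the group attached, with this one change replacing methoxy with a chain that carries a five-membered non-aromatic ring containing nitrogen. Nothing available explains the size of this step, so the result records the effect of the change without giving its cause.

The compounds shown cannot separate the contributions of the ring, its nitrogen and the methylene link, so it remains open whether a plain dimethylaminomethyl group, a (piperidin-1-yl)methyl or (morpholin-4-yl)methyl group, or a pyrrolidine ring attached directly to the aromatic carbon would give a similar step. From the compounds shown here alone, it is also open whether the same change would have a comparable effect on the core of compound 1, or with a carboxylic acid in place of the ethyl ester.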